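A new side chain on compound 3

The compounds below may be only part of what the source reports. "The series", "measured", "known", "first", "only" and "open" are said of these compounds alone.

Compound 1 `Cc1nc(CS(=O)(=O)c2ccccc2)c([N+](=O)[O-])n1C`: > 846000 nM, which is a limit of the assay and not a number.
Compound 2 `Cc1ccc(S(=O)(=O)Cc2nc(C)n(C)c2[N+](=O)[O-])cc1`: 242000 nM
Compound 3 `Cc1nc(CS(=O)(=O)c2ccc(Br)cc2)c([N+](=O)[O-])n1C`: 326000 nM

All three results come from an ADME assay on THP-1 cells (Homo sapiens) for cytotoxicity, read by flow cytometry and propidium iodide staining, with a stated time of 72 h; a lower number here means a stronger inhibitor, a higher number a weaker inhibitor. The two actual numbers are separated by a 1.3-fold higher number from compound 2 to compound 3 (0.13 log units; within the scatter). Compound 3 therefore stands level with compound 2 on these results. Measured against the limit of compound 1, the other two steps are an at least 3.4-fold lower number from compound 1 to compound 2 (0.54 log units; beyond the scatter) and an at least 2.5-fold lower number from compound 1 to compound 3 (0.41 log units; beyond the scatter).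

Compound 4 `Cc1nc(CS(=O)(=O)c2ccc(Br)cc2)c([N+](=O)[O-])n1CC(C)O` has not yet been measured. It differs from compound 3 as follows: 1-hydroxyethyl in place of hydrogen on a saturated chain carbon bound to an aromatic nitrogen. Put another way, a methyl group becomes 2-hydroxypropyl. Within the data shown here, none of the measured steps touches this place, since all of them changed a group on an aromatic carbon. Going by these compounds, they offer only a rough sense of scale, and the new chain remains untested here. With compound 3 at 326000 nM as the starting point, no step beyond the scatter is expected in this assay, and no direction is favoured. The expected change is a 1.1-fold higher number from compound 3 to compound 4 (0.03 log units; within the scatter). For compound 4 the estimated value is 350000 nM, with an expected range from 130000 nM to 850000 nM.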

Compound 4, half-maximal inhibitory concentration: 126000 nM
Compound 4: middle estimate off by 2.8-fold (0.44 log units), on the high side, and the stated range ends above it.
By their numbers in this assay, from the lowest: compounds 4, 2 and 3 (each within the scatter of the next, the first and the last beyond it). At a limit, above all of these: compound 1.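

Until now, every step in this assay had changed a group on an aromatic carbon, so the compounds said nothing about the saturated chain carbon bound to an aromatic nitrogen. This result shows that the position matters in this assay: placing 1-hydroxyethyl there, which turns methyl into 2-hydroxypropyl, gives a 2.6-fold lower number from compound 3 to compound 4 (0.41 log units; beyond the scatter), a modest step. The results shown offer no explanation for this step.

Going by these compounds, it remains open whether the hydroxyl group or the added chain itself produces the change, and a plain propyl chain in this place would separate the two. Among these compounds, an amine or a carboxylic acid on this chain, or a longer chain, could show how far the number can move, and the change is so far seen only with the bromo group on the core.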